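A Methoxy Swap on the Amide Nitrogen

This account rests on a few compounds, and the source may have more. Where it says the series, first, only, none or still open, it means among the compounds named here.

Compound 1 `CCOc1ccc(NC(=O)c2cccc(/C=C3\CC(=O)N(c4ccccc4)C3=O)c2)cc1` was examined in an ADME assay on NCM460 cells (Homo sapiens) for cytotoxicity, read by MTT assay, with a stated time of 72 h; on this read-out higher numbers stand for weaker inhibition and lower numbers for stronger inhibition. In this assay compound 1 returns only a limit, > 100000 nM, not a measured number. Compound 2 `CCCCCN1C(=O)C/C(=C\c2cccc(C(=O)Nc3cccc(CC)c3)c2)C1=O`, built on the same core, likewise gives only a limit in this assay, > 100000 nM. Among the measured compounds shown here, both results sit at the limit of > 100000 nM in this assay, at which 2 of the 2 values shown sit, so nothing measured here separates the two, and compound 1 stands at the limit together with the one other value shown. Compound 3 `COc1ccc(OC)c(NC(=O)c2cccc(/C=C3\CC(=O)N(c4ccccc4)C3=O)c2)c1` differs from compound 1 in a single place: 2,5-dimethoxyphenyl in place of 4-ethoxyphenyl on an amide-type nitrogen. For the measured compounds named here, no step between measured compounds is available to guide the size of the change, and the two values at hand are both limits. In this assay the step expected is a number no higher from compound 1 to compound 3 (the limit leaves the size open), none beyond the scatter, with compound 3 expected to remain at the limit. Compound 3 is estimated at 100000 nM, within a range from 50000 nM to 200000 nM.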

Compound 3, half-maximal inhibitory concentration: > 100000 nM
Compound 3 ended at the assay's limit; the forecaster's own chance of this, stated with the estimate: 80%; the middle value sits exactly at the limit.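

Compound 1 and compound 3 both give only a limit, so no step can be read between them: the limit of > 100000 nM in this assay, at which 3 of the 3 values shown sit.

Still open is whether 2,5-dimethoxyphenyl in place of 4-ethoxyphenyl changes cytotoxicity at all, and at what concentration any of these compounds would reach half-maximal inhibition.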